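Dropping the Aminoethyl Chain from Compound 1

The compounds below may be only part of what the source reports. "The series", "measured", "known", "first", "only" and "open" are said of these compounds alone.

Measured compounds:
- compound 1 `NCCn1ncc2c(NCc3ccccc3[N+](=O)[O-])cc(C(F)(F)F)cc21`: > 100000 nM
- compound 2 `O=C(O)CNc1cccc(CNc2cc(C(F)(F)F)cc3[nH]ncc23)c1`: > 100000 nM

Compound 1 `NCCn1ncc2c(NCc3ccccc3[N+](=O)[O-])cc(C(F)(F)F)cc21` was examined in an assay for inhibition of Tryptophan 2,3-dioxygenase (Homo sapiens), with stated times of 10 min and 60 min (on this read-out higher numbers stand for weaker inhibition and lower numbers for stronger inhibition), where compound 1 gives > 100000 nM, a limit of the assay and not a number. Compound 2 `O=C(O)CNc1cccc(CNc2cc(C(F)(F)F)cc3[nH]ncc23)c1` was tested in this assay as well, and compound 2 gives > 100000 nM, again a limit rather than a number. Within the data shown here, compound 1 therefore stands at the limit of > 100000 nM in this assay, at which 2 of the 2 values shown sit, so nothing more precise than that ceiling is known for it, and the one further value is a limit too.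

Compound 3 `O=[N+]([O-])c1ccccc1CNc1cc(C(F)(F)F)cc2[nH]ncc12` is related to compound 1 by one change: hydrogen in place of 2-aminoethyl on an aromatic nitrogen. Among the measured compounds shown here, no pair of measured compounds differing in a single place has been reported, so no measured step can be consulted. With both known values sitting at the limit, he expects the change from compound 1 to compound 3 to bring no step beyond the scatter in this assay, in either direction. Compound 3 is accordingly estimated at 100000 nM, with a range from 20000 nM to 300000 nM. The estimated step of a number no higher from compound 1 to compound 3 (the limit leaves the size open) is expected to be effectively flat.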

Compound 3, half-maximal inhibitory concentration: 2550 nM
Compound 3: the middle estimate sits 39-fold (1.59 log units) above what was measured, outside the stated range (below it).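

The change appears in this assay as an at least 39-fold lower number from compound 1 to compound 3 (1.59 log units; beyond the scatter). Among these compounds, this shows that the aromatic nitrogen is not indifferent to what it carries: with hydrogen there, compound 3 gives a real number, whereas the earlier compounds offered only limits and no measured step to show that this position mattered. The size of the step stays open on one side because the value for compound 1 is a limit of the assay and not a number: the limit of > 100000 nM in this assay, at which 2 of the 3 values shown sit.

From the compounds shown here alone, what remains open is whether the loss follows the amine at the end of the 2-aminoethyl chain or the presence of any chain at all, a question that a plain methyl or ethyl group on this nitrogen would help to separate. Also open, going by these compounds, is how a longer chain, or a chain ending in a hydroxyl group, an amide or a carboxylic acid, would read in this assay on the core of compound 3.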